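The compounds below may be only part of what the source reports. "The series", "measured", "known", "first", "only" and "open" are said of these compounds alone.

Only a thin set of readings frames this comparison. In an ADME assay on KB cells (Homo sapiens) for cytotoxicity, read by MTT assay, with a stated time of 72 h (on this read-out higher numbers stand for weaker inhibition and lower numbers for stronger inhibition), compound 1 (`COc1cc(C2=C(c3ccc(OCC(=O)O)cc3)C(O)CC2=O)cc(OC)c1OC`) gives > 100 ug/mL, which is a limit of the assay and not a number. Compound 2 (`COc1ccc(C2=C(c3cc(OC)c(OC)c(OC)c3)C(=O)CC2O)cc1`) offers no firmer footing, since its entry reads "not determined" (no result reported). Within the data shown here, it therefore has no number of its own, and the only other reading beside it is that limit.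

The next compound to be tested is compound 3 (`CCOC(=O)COc1ccc(C2=C(c3cc(OC)c(OC)c(OC)c3)C(=O)CC2O)cc1`), which has not yet been measured. The structural change is ethoxycarbonyl in place of hydrogen on a saturated chain carbon bound to an oxygen on an aromatic ring: ethoxycarbonyl replaces hydrogen on a saturated chain carbon bound to an oxygen on an aromatic ring, so methoxy becomes (ethoxycarbonyl)methoxy.

Among the measured compounds shown here, no measured pair shows what this kind of change does, and compound 2 has no number to start from, so any forecast is loose. A step of moderate size toward weaker inhibition, meaning a higher number, is the tentative expectation. In this assay, the estimated value for compound 3 is 3 ug/mL, with an expected range from 0.05 ug/mL to 100 ug/mL.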

Compound 3, half-maximal inhibitory concentration: > 100 ug/mL
Compound 3 was reported as a limit; the forecaster's own chance of this, stated with the estimate: 20%; middle value at least 33-fold (1.52 log units) away from the limit.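

No step can be read from compound 1 to compound 3, because both readings are limits of the assay and not numbers: the limit of > 100 ug/mL in this assay, at which 2 of the 3 values shown sit.

Compound 2 has no reported result to set against compound 3, so the compounds shown leave open what changing methoxy to (ethoxycarbonyl)methoxy does in this assay.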